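The compounds below may be only part of what the source reports. "The series", "measured", "known", "first", "only" and "open" are said of these compounds alone.

Of the compounds shown here, two have been measured so far in a functional assay on HeLa cells (Homo sapiens) for cytotoxicity, read by CCK-8 assay; on this read-out lower numbers stand for stronger inhibition and higher numbers for weaker inhibition. Compound 1 `Oc1cccc(-c2cc(-c3cccs3)cc(-c3ccccc3O)n2)c1` carries a 3-hydroxyphenyl group together with a thiophen-2-yl group on the shared core. In this assay compound 1 reaches only the limit of the measurement, > 50000 nM. Compound 2 `Oc1ccccc1-c1cc(-c2ccsc2)cc(-c2ccccc2O)n1` carries two 2-hydroxyphenyl groups and a thiophen-3-yl group on the same core. In this assay compound 2 likewise stops at the limit, > 50000 nM. For the measured compounds named here, compound 2 therefore stands exactly where all the numbers so far stand: the limit of > 50000 nM in this assay, at which 2 of the 2 values shown sit. Going by the values given here, no measured pair differs in a single place, so no measured step is available to lean on.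

Compound 3 `Oc1cccc(-c2cc(-c3ccsc3)cc(-c3ccccc3O)n2)c1` is not yet measured. It differs from compound 2 in that (3-hydroxyphenyl in place of 2-hydroxyphenyl on an aromatic carbon). The thiophen-3-yl group and the other 2-hydroxyphenyl group stay in place. Compound 1, which also carries a 3-hydroxyphenyl group, reaches only the limit, > 50000 nM. On that basis compound 3 is expected to remain at the limit, the expected step being a step that the limit leaves unreadable from compound 2 to compound 3, nothing beyond the scatter. Compound 3 is thus estimated at 60000 nM, between 20000 nM and 200000 nM.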

Compound 3, half-maximal inhibitory concentration: > 50000 nM
Compound 3 was reported as a limit (the forecaster's own chance of this, stated with the estimate: 80%); the middle value does not contradict the limit.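

Compound 3 reads only as a limit in this assay, as do compound 1 and compound 2, so neither the step from compound 2 to compound 3 nor the step from compound 1 to compound 3 can be read: the limit of > 50000 nM in this assay, at which 3 of the 3 values shown sit.

The compounds shown leave open whether any change on the shared core gives a measurable value in this assay.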